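The source may hold more compounds than are shown below. What is called first, only, known or untested is meant among the compounds shown, and "the series" means these compounds.

Compound 1 `COc1ccccc1/C=C/C[C@H]1C[C@@H]([C@@H](O)c2ccccc2)CO[C@@H]1c1ccccc1`: 14700 nM
Compound 2 `O[C@@H](c1ccccc1)[C@H]1CO[C@H](c2ccccc2)[C@@H](C/C=C/C2CCCCC2)C1`: 6440 nM

In a functional assay on HeLa cells (Homo sapiens) for cytotoxicity, read by WST assay, with a stated time of 48 h (a lower number here means a stronger inhibitor, a higher number a weaker inhibitor), compound 2 holds the lowest of the two numbers measured; compound 1 stands a modest distance higher. Among the measured compounds shown here, the only measured step, a 2.3-fold lower number from compound 1 to compound 2 (0.36 log units; beyond the scatter), exchanged a group at the same place that changes now. Compound 3 `O[C@@H](c1ccccc1)[C@H]1CO[C@H](c2ccccc2)[C@@H](C/C=C/c2ccncc2)C1` differs from compound 2 in one place: pyridin-4-yl in place of cyclohexyl on a double-bonded chain carbon bound to a double-bonded chain carbon. Since the earlier step moved from an aromatic ring to cyclohexyl and lowered the number, the return to an aromatic ring is expected to raise it modestly: a 1.5-fold higher number from compound 2 to compound 3 (0.17 log units; within the scatter). Compound 3 is therefore expected to give about 9500 nM, within 3000 nM to 30000 nM.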

Compound 3, half-maximal inhibitory concentration: > 100000 nM
Compound 3 gave a limit, no number (the forecaster's own chance of this, stated with the estimate: 10%); middle value at least 10-fold (1.02 log units) away from the limit.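

Compound 3 gives a limit and not a number: the limit of > 100000 nM in this assay, at which 1 of the 3 values shown sits. The position proves far less forgiving than the first two compounds suggested: pyridin-4-yl brings an at least 15-fold higher number from compound 2 to compound 3 (1.19 log units; beyond the scatter), though it holds the same count of heavy atoms as cyclohexyl. Being aromatic does not settle the outcome either, since replacing the aromatic 2-methoxyphenyl gives an at least 6.8-fold higher number from compound 1 to compound 3 (0.83 log units; beyond the scatter).

Still open, on these data alone, is whether the ring nitrogen itself or its place in the ring matters. Plain phenyl and pyridin-3-yl at this place would help separate the two.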